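Hydroxy to methyl on the core of compound 1

The compounds below may be only part of what the source reports. "The series", "measured", "known", "first", "only" and "open" are said of these compounds alone.

Among the measured compounds shown here, compound 1 `O=C(N/N=C/c1coc2ccc(O)cc2c1=O)c1cc2ccccc2[nH]1` is the only member with a number in an assay for inhibition of Alpha amylase (Homo sapiens); on this read-out lower numbers stand for stronger inhibition and higher numbers for weaker inhibition: compound 1 gives 151000 nM. Compound 2 `Cc1ccc(S(=O)(=O)Oc2ccc(/C=N/NC(=O)Cc3ccccn3)cc2)cc1` sits at a limit of the assay, > 200000 nM. Compound 3 `Cc1ccc(S(=O)(=O)Oc2ccc(/C=N/NC(=O)c3nc4ccccc4[nH]3)cc2)cc1` likewise returns a limit, > 200000 nM. The step that the two limits leave unreadable from compound 2 to compound 3 cannot be read, since both ends rest at the limit of > 200000 nM in this assay, at which 2 of the 3 values shown sit. Compound 4 `Cc1ccc2occ(/C=N/NC(=O)c3cc4ccccc4[nH]3)c(=O)c2c1` differs from compound 1 by methyl in place of hydroxy on an aromatic carbon. For the measured compounds named here, no measured step touches this change; the single step on record is unreadable and concerns another part of the molecule. Starting from compound 1 at 151000 nM, a step hardly beyond the scatter is expected, weaker rather than stronger. The estimate for compound 4 is 200000 nM, range 80000 nM to 500000 nM, a step of a 1.3-fold higher number from compound 1 to compound 4 (0.12 log units; within the scatter).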

Compound 4, half-maximal inhibitory concentration: > 200000 nM
Compound 4: a limit, no number; the forecaster's own chance of this, stated with the estimate: 50%; the middle value sits exactly at the limit.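

In this assay, among the compounds shown here, the change from hydroxy to methyl gives an at least 1.3-fold higher number from compound 1 to compound 4 (0.12 log units; that floor lies within the scatter) and so marks the first readable step at this position. That step is a floor only, as compound 4 is a limit and not a number. The series now rests largely at one limit: the limit of > 200000 nM in this assay, at which 3 of the 4 values shown sit.

As far as these compounds go, how far the step extends beyond that floor stays open, and so does whether the hydroxy itself is needed on the core of compound 1. A methoxy or an amine at this position would test how specific the hydroxy is.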